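Chain Extension at the Amine Side of Compound 2

The source may hold more compounds than are shown below. What is called first, only, known or untested is meant among the compounds shown, and "the series" means these compounds.

Measured in a functional assay on MCF7 cells (Homo sapiens) for antiproliferative activity, read by MTT assay, with a stated time of 72 h; a higher number here means a weaker inhibitor, a lower number a stronger inhibitor:
Compound 1, `CCN1CCN(c2cc(C)c3cc(NC(=O)c4ccc(F)cc4)ccc3n2)CC1`: 4030 nM
Compound 2, `CNc1cc(C)c2cc(NC(=O)c3ccc(Cl)c(Cl)c3)ccc2n1`: 2520 nM
Compound 3, `CCN1CCN(c2cc(C)c3cc(NC(=O)c4ccccc4C)ccc3n2)CC1`: 10900 nM

Compound 2 gives the lowest of the three numbers; compound 1 lies within the scatter of it, compound 3 beyond it. Compound 4, `Cc1cc(NCCN2CCCCC2)nc2ccc(NC(=O)c3ccc(Cl)c(Cl)c3)cc12`, is compound 2 with (piperidin-1-yl)methyl in place of hydrogen on a saturated chain carbon bound to a nitrogen on an aromatic ring. Going by the values given here, the one single-point step measured, a 2.7-fold higher number from compound 1 to compound 3 (0.43 log units; beyond the scatter), concerns the group on a carbonyl carbon and says nothing about the amine side; compound 1 and compound 2 differ in two places and show only that their values sit close together. Among the compounds with values here, no measured step touches the amine chain, so the estimated step is small, a 1.1-fold lower number from compound 2 to compound 4 (0.06 log units; within the scatter), not beyond the scatter. Compound 4 is expected to give about 2200 nM in this assay, within 800 nM to 6500 nM.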

Compound 4, half-maximal inhibitory concentration: 1190 nM
Compound 4: middle estimate off by 1.8-fold (0.27 log units), on the high side; measured number inside the range.
By their numbers in this assay, from the lowest: compound 4; then compounds 2 and 1 (each within the scatter of the next); then compound 3.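

The amine side now has its first measured step: in this assay there is a 2.1-fold lower number from compound 2 to compound 4 (0.33 log units; beyond the scatter). This position therefore takes the (piperidin-1-yl)methyl extension, with its 7 heavy atoms, without loss of activity, and the modest gain lies beyond the scatter. No measurement shown here accounts for the gain.

Still open, as far as these compounds go, is whether the gain depends on the piperidine ring or on the ethyl chain; a morpholine ring, a dimethylamino end group or a longer propyl chain would separate these. Also open, from the compounds shown here alone, is whether it carries over to the 4-fluorophenyl and 2-methylphenyl amides.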